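The source may report more compounds than this note shows. Statements on the series, on what has been measured and on what is new or still open speak of the compounds shown alone.

Working notes on the series.

Compound 1 `Cn1c(-c2ccc(NC(=O)CSc3nc4ccccc4o3)cc2)nc(-c2ccccc2)c1-c1ccccc1` is the reference point. Going by the values given here, in a functional assay on HT-29 cells (Homo sapiens) for cytotoxicity, read by MTT assay, with a stated time of 24 h, tested at 1.6 ug/mL (a lower number here means a weaker effect, a higher number a stronger effect of the compound at the concentration tested), compound 1 gives 41%, the higher of the two numbers so far; the nearest is compound 2 `Cn1cnnc1SCC(=O)Nc1ccc(-c2nc(-c3ccccc3)c(-c3ccccc3)n2C)cc1`, which in this assay gives 40.8%. Among the compounds with values here, the only measured step, a number 0.2 percentage points lower from compound 1 to compound 2 (within the scatter), exchanges one heteroaromatic group on the sulfur for another and leaves the read-out essentially where it was, so compound 1 cannot be called the stronger of the two.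

Compound 3 `Cn1c(-c2ccc(NC(=O)CSC3=NCCS3)cc2)nc(-c2ccccc2)c1-c1ccccc1` is not yet measured in this assay. It differs from compound 1 as follows: a group of 5 heavy atoms (3 carbon, 1 nitrogen, 1 sulfur; one five-membered non-aromatic ring with 2 hetero atoms) in place of a group of 9 heavy atoms (7 carbon, 1 nitrogen, 1 oxygen; one five-membered aromatic ring with 2 hetero atoms, one six-membered aromatic ring of carbon only), on a sulfur. Within the data shown here, the change sits at the same sulfur as the step from compound 1 to compound 2, so that step is the one piece of evidence that bears on it, and it was within the scatter. On that basis no step beyond the scatter is expected in this assay for compound 3, though the group entering here is smaller and non-aromatic, so a modest fall is not excluded. Compound 3 is therefore estimated at 38%, with a range from 22% to 54%, corresponding to an expected step of a number 3 percentage points lower from compound 1 to compound 3 (within the scatter).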

Compound 3, a percentage reported as activity, at one concentration (the size of the read-out at that concentration, not a potency): 30.4%
Compound 3: middle estimate off by 7.6 percentage points, on the high side; low and high end bracket the measured number.
By their numbers in this assay, from the lowest: compound 3; then compounds 2 and 1 (each within the scatter of the next).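

In this assay the group on the sulfur proves not to be freely exchangeable: 1,3-benzoxazol-2-yl gives way to the five-membered non-aromatic ring with a number 10.6 percentage points lower from compound 1 to compound 3 (beyond the scatter) and the same ring replaces 4-methyl-4H-1,2,4-triazol-3-yl with a number 10.4 percentage points lower from compound 2 to compound 3 (beyond the scatter). The earlier step showed only that two aromatic groups of different size could be exchanged without leaving the scatter; among these three compounds, the non-aromatic group is the one that stands apart, and the loss is similar whichever aromatic group it replaces. The groups leaving and entering in the step from compound 1 have equal counts of hydrogen-bond donors and acceptors, so those counts do not separate them, and no measurement on hand accounts for the lower read-out.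

The compounds shown leave open whether the ring's lack of aromaticity or its ring sulfur goes with the lower read-out, a question that an aromatic thiazol-2-yl group on the same sulfur would address. They also leave open how a simple methyl or a carboxylic acid in this place would read, and all three numbers come from a single concentration, so they say nothing about potency.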